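The source may report more compounds than this note shows. Statements on the series, on what has been measured and on what is new or still open speak of the compounds shown alone.

In a functional assay on DU-145 cells (Homo sapiens) for inhibition, read by trypan blue exclusion, with a stated time of 96 h (on this read-out higher numbers stand for weaker inhibition of growth and lower numbers for stronger inhibition of growth), two compounds sharing one core have been measured so far. Compound 1 (`Cc1ccc(C)c(/C=C(\C(=O)c2ccc(Br)cc2)S(=O)(=O)Cc2ccc(F)cc2)c1`) gives 1000 nM, while compound 2 (`CN(C)c1ccc(/C=C(\C(=O)c2ccc(Br)cc2)S(=O)(=O)Cc2ccc(F)cc2)cc1`) gives 50000 nM, the higher of the two numbers and so the weaker inhibition of growth. Compound 3 (`COc1ccccc1/C=C(\C(=O)c1ccc(Br)cc1)S(=O)(=O)Cc1ccc(F)cc1`) has not yet been measured, and it differs from compound 2 in one group: 2-methoxyphenyl in place of 4-(dimethylamino)phenyl on a double-bonded chain carbon bound to a double-bonded chain carbon. Among the compounds with values here, only one measured step bears on this change, a 50-fold higher number from compound 1 to compound 2 (1.70 log units; beyond the scatter). That large step involved the same place on the chain and the same departing group, read in reverse. Compound 3, like compound 1, lacks the 4-(dimethylamino)phenyl, so a large move towards a lower number is expected, although a single pair cannot show how far it will go. The expected step is a 17-fold lower number from compound 2 to compound 3 (1.22 log units; beyond the scatter). For compound 3, the estimated value is 3000 nM, with an expected range from 600 nM to 15000 nM.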

Compound 3, concentration for 50% growth inhibition: 25000 nM
The estimate for compound 3 lay 8.3-fold (0.92 log units) below the measured number; the whole stated range lies below it.
By their numbers in this assay, from the lowest: compound 1; then compounds 3 and 2 (each within the scatter of the next).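

In this assay, the step of a 2.0-fold lower number from compound 2 to compound 3 (0.30 log units; within the scatter) stays within the usual scatter, so at this place on the chain the 2-methoxyphenyl and the 4-(dimethylamino)phenyl cannot be told apart. The step of a 25-fold higher number from compound 1 to compound 3 (1.40 log units; beyond the scatter) lies beyond the scatter, which shows that removing the 4-(dimethylamino)phenyl does not by itself bring the number down to that of compound 1; of the three groups tried here, only the 2,5-dimethylphenyl stands apart. No measurement at hand accounts for this difference.

On these data alone, it remains open whether both methyl groups of the 2,5-dimethylphenyl are needed for the lower number. As far as these compounds go, it is also open whether a plain phenyl, or a phenyl carrying a single methyl group or a chlorine atom, would read like compound 1 or like compounds 2 and 3.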